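Benzylseleno for methylsulfanyl exchange on two cores

This account rests on a few compounds, and the source may have more. Where it says the series, first, only, none or still open, it means among the compounds named here.

Compound 1 `CS/C(=N\C(=O)c1csc([N+](=O)[O-])c1)NC(=O)c1csc([N+](=O)[O-])c1` gives 44700 nM in a functional assay on MCF7 cells (Homo sapiens) for cytotoxicity, read by MTT assay, with a stated time of 72 h; on this read-out higher numbers stand for weaker inhibition of growth and lower numbers for stronger inhibition of growth. Compound 2 `O=C(/N=C(/NC(=O)c1csc([N+](=O)[O-])c1)[Se]Cc1ccccc1)c1csc([N+](=O)[O-])c1` gives 24400 nM in this assay. The change between them is a group of 8 heavy atoms (7 carbon, 1 selenium; one six-membered aromatic ring of carbon only) in place of a group of 2 heavy atoms (1 carbon, 1 sulfur; no ring), on a carbon with a double bond to nitrogen, and it made a 1.8-fold lower number from compound 1 to compound 2 (0.26 log units; within the scatter). Compound 3 `CS/C(=N\C(=O)c1cnc2ccccc2c1)NC(=O)c1cnc2ccccc2c1` gives 23900 nM in this assay; how its core differs from the core of compound 1 is not broken down here, and the values of compound 3 and compound 2 lie within the scatter of each other. Compound 4 `O=C(/N=C(/NC(=O)c1cnc2ccccc2c1)[Se]Cc1ccccc1)c1cnc2ccccc2c1` carries the same change on the core of compound 3: a group of 8 heavy atoms (7 carbon, 1 selenium; one six-membered aromatic ring of carbon only) in place of a group of 2 heavy atoms (1 carbon, 1 sulfur; no ring), on a carbon with a double bond to nitrogen. It is not yet measured in this assay. The step from compound 3 to compound 4 is expected at a 1.6-fold lower number from compound 3 to compound 4 (0.20 log units; within the scatter), set beside a 1.8-fold lower number from compound 1 to compound 2 (0.26 log units; within the scatter), and rests on that single earlier step alone. Compound 4 is therefore estimated at 15000 nM, expected to fall between 6000 nM and 40000 nM.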

Compound 4, concentration for 50% growth inhibition: 23600 nM
Beside the measured number, compound 4's estimate is 1.6-fold (0.20 log units) below it; low and high end bracket the measured number.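

In this assay the exchange of methylsulfanyl for benzylseleno gives a 1.0-fold lower number from compound 3 to compound 4 (0.01 log units; within the scatter). The two cores do not differ in their response to this change: the same change on two cores in this assay, a 1.8-fold lower number (0.26 log units; within the scatter) from compound 1 to compound 2 and a 1.0-fold lower number (0.01 log units; within the scatter) from compound 3 to compound 4, 1.8-fold (0.26 log units) apart, within the scatter of two such steps. Within the data shown here, this shows only that the exchange leaves the number within the scatter on both cores; it does not show that the change has a real effect that carries over, and two cores are too few to support a rule for the series.

On these data alone, the selenium and the benzyl ring change together in both pairs, so their separate contributions remain open. Also open, as far as these compounds go, is how a benzylsulfanyl group or an amine would read on the carbon with a double bond to nitrogen.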